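Swapping Acetamido for Dimethylcarbamoyl on the Core of Compound 1

A few compounds are considered here, and "the series" means these few. Any claim that something is new, unique, unknown or untested is made for them only; others in the source may bear on it.

Of the compounds shown here, three sharing a core have been tested in an ADME assay on the whole organism (Macaca fascicularis) for metabolic stability, read by LC-MS, using cassette dosing, at a dose of 1 mg/kg by the oral route; a lower number here means that the compound disappears faster, a higher number that the compound lasts longer. Compound 1 `CCCCN(c1nc2c(NC(C)=O)cccc2o1)[C@H](C)c1ccc(-c2ccccc2-c2nnn[nH]2)cc1` gives 2.2 h in this assay. Compound 2 `C[C@H](c1ccc(-c2cc(F)ccc2-c2nc(=O)o[nH]2)cc1)N(CC1CC1)c1nc2c(C(=O)O)cccc2o1` gives 4.1 h in this assay, and compound 3 `CCCCN(c1nc2c(C(=O)O)cccc2o1)[C@H](C)c1ccc(-c2cc(Cl)ccc2-c2nc(=O)o[nH]2)cc1` gives 2 h in this assay. Compound 1 sits in the middle of these three numbers, with compound 3 nearest to it and compound 2 furthest from it, yet both gaps fall within the usual scatter of repeated measurements, so the three compounds cannot be told apart on these numbers alone.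

The next compound, compound 4 `CCCCN(c1nc2c(C(=O)N(C)C)cccc2o1)[C@H](C)c1ccc(-c2ccccc2-c2nnn[nH]2)cc1`, differs from compound 1 in one place on the core: dimethylcarbamoyl in place of acetamido on an aromatic carbon. For the measured compounds named here, no pair of measured compounds differing in a single place is available here, so there is no measured step to lean on. The three measured values lie close together despite larger differences elsewhere in the structures, and a single change of this kind is expected to give a step from compound 1 to compound 4 of a 1.1-fold higher number from compound 1 to compound 4 (0.06 log units; within the scatter), that is, nothing beyond the scatter. Compound 4 is therefore estimated to give 2.5 h in this assay, within a range from 1.2 h to 5 h.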

Compound 4, half-life: 3.2 h
Compound 4: middle estimate off by 1.3-fold (0.11 log units), on the low side; low and high end bracket the measured number.
By their numbers in this assay, from the lowest: compounds 3, 1, 4 and 2 (each within the scatter of the next, the first and the last beyond it).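

For the compounds shown here, compound 1 and compound 4 form the first pair in this set that differs in only one place, so this position on the core can be read on its own. In this assay, dimethylcarbamoyl in place of acetamido on this aromatic carbon gives a 1.5-fold higher number from compound 1 to compound 4 (0.16 log units; within the scatter), so this single pair shows no measurable effect on the half-life, even though acetamido carries a hydrogen-bond donor and dimethylcarbamoyl carries none. Nothing available here explains the size of this step, and with a single pair on one background it cannot be called a general rule for this position.

Compound 2 and compound 3 carry a carboxylic acid on the core, but they also differ from compound 1 elsewhere, so they cannot show what that group does at this position on its own. From the compounds shown here alone, it remains open whether an amine, a methoxy group or a nitrile on this same aromatic carbon would also stay within the scatter, or whether a group of that kind would shift the half-life clearly in either direction.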